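Oxadiazole aryl swap: pyridin-3-yl for 4-methylphenyl

The compounds below may be only part of what the source reports. "The series", "measured", "known", "first", "only" and "open" are said of these compounds alone.

The series shares one core and varies the aryl group on the five-membered ring. Compound 1 `CS(=O)(=O)c1ccc(-c2cnc3[nH]cc(-c4nnc(-c5ccccn5)o4)c(=O)c3c2)cc1` was measured in a functional assay on HCT-116 cells (Homo sapiens) for inhibition, read by MTT assay, with a stated time of 24 h, tested at 5 uM (on this read-out lower numbers stand for less inhibition of growth and higher numbers for more inhibition of growth at the one concentration tested), and gives 11.3%. Compound 2 `Cc1ccc(-c2nnc(-c3c[nH]c4ncc(-c5ccc(S(C)(=O)=O)cc5)cc4c3=O)o2)cc1` gives 20.4% in this assay. Going by the values given here, the single measured step, a number 9.1 percentage points higher from compound 1 to compound 2 (within the scatter), lies within the scatter, so compound 2 and compound 1 stand within the usual spread of each other; compound 2 carries the larger of the two numbers only nominally, with compound 1 as its nearest neighbour.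

Compound 3 `CS(=O)(=O)c1ccc(-c2cnc3[nH]cc(-c4nnc(-c5cccnc5)o4)c(=O)c3c2)cc1` is now to be measured. It differs from compound 2 in one place: pyridin-3-yl in place of 4-methylphenyl on an aromatic carbon. Among the compounds with values here, the only step that bears on this change is the one from compound 1 to compound 2, which ran in the opposite sense, exchanging a pyridyl ring for 4-methylphenyl, and stayed within the scatter. Returning to a pyridyl ring, here pyridin-3-yl, is therefore expected to give no step beyond the scatter in this assay, with at most a nominal drift downward of a number 6.4 percentage points lower from compound 2 to compound 3 (within the scatter). Compound 3 is estimated at 14%, in the range 3% to 26%.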

Compound 3, percent growth inhibition at one concentration: 9.26%
For compound 3 the middle estimate is 4.7 percentage points above the measured one, within the range that was stated.
By their numbers in this assay, from the lowest: compounds 3, 1 and 2 (each within the scatter of the next, the first and the last beyond it).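

In this assay this aryl position now shows a step that can be read, a number 11.1 percentage points lower from compound 2 to compound 3 (beyond the scatter), for pyridin-3-yl in place of 4-methylphenyl on the aromatic carbon of the five-membered ring, whereas the earlier exchange of pyridin-2-yl for 4-methylphenyl did not separate its pair. The two pyridyl groups themselves stand together, with pyridin-3-yl in place of pyridin-2-yl giving a number 2 percentage points lower from compound 1 to compound 3 (within the scatter), so compound 1 remains within the scatter of both other compounds and the separation rests on compound 2 and compound 3 alone. No measurement at hand accounts for this step.

Going by these compounds, whether pyridin-4-yl stands with the other two pyridyl groups remains open, as does what an aminomethyl group or a carboxylic acid on the phenyl ring, or a saturated ring such as morpholine at this carbon, would do to the number. All readings come from a single concentration, so the ranking of these compounds at other concentrations, and whether this modest step would hold across a full concentration series, also remains open.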